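The compounds below may be only part of what the source reports. "The series", "measured", "known", "first", "only" and "open" are said of these compounds alone.

Measured compounds and their values in kinetic solubility:
compound 1 `COc1ccc(S(=O)(=O)Nc2ccc(CN3CCN(C(=O)C4CN(C(C)=O)C4)CC3)cc2)cc1` – >= 511000 nM
compound 2 `Cc1ccc(S(=O)(=O)Nc2ccc(CN[C@@H]3CCN(C(=O)c4cccc(Cl)c4)C3)cc2)cc1` – 75000 nM
compound 3 `Cc1ccc(S(=O)(=O)Nc2ccc(CNC3CN(C(=O)c4cccc(Cl)c4)C3)cc2)cc1` – 70000 nM

All three were run in a physicochemical assay for solubility, measured as kinetic solubility; on this read-out higher numbers stand for higher solubility and lower numbers for lower solubility. For compound 1 the entry >= 511000 nM is a limit of the assay and not a number, as noted in the limit of >= 511000 nM in this assay, at which 1 of the 3 values shown sits. Of the two numbers that remain, compound 2 gives 75000 nM and holds the highest figure, while compound 3 gives 70000 nM; the gap between compound 2 and compound 3 lies within the scatter of repeated measurements, so these two compounds cannot be told apart on this read-out.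

Compound 4 `Cc1ccc(S(=O)(=O)Nc2ccc(CN[C@H]3CCN(C(=O)c4cccc(Cl)c4)C3)cc2)cc1` has not yet been measured in this assay. Set against compound 2, the change is the two compounds have the same atoms and bonds and differ only in configuration as drawn: 1 of 1 stereo elements differ; a stereocentre at a saturated ring carbon is drawn R in compound 2 and S in compound 4. Among the measured compounds shown here, no step between two measured compounds is available that would show how such a change acts here, and compound 1 offers no guidance on it.

Since the two compounds share every atom and bond, the expectation is that compound 4 behaves like compound 2 in this assay, with a step of no more than the usual scatter in either direction, expected as no change at the digits printed from compound 2 to compound 4 (within the scatter). The estimated value for compound 4 is 75000 nM, within a range from 40000 nM to 140000 nM.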

Compound 4, solubility: 72000 nM
Beside the measured number, compound 4's estimate is 1.0-fold (0.02 log units) above it; the measured number falls inside the stated range.
By their numbers in this assay, from the lowest: compounds 3, 4 and 2 (each within the scatter of the next). At a limit, above all of these: compound 1.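

In this assay, among the compounds shown here, the pair gives the first step between two measured compounds in this set: a 1.0-fold lower number from compound 2 to compound 4 (0.02 log units; within the scatter). Redrawing the stereocentre at this saturated ring carbon from R to S therefore leaves no difference that this read-out can resolve, so compound 2 and compound 4 cannot be told apart here. This reading is a clean one, as nothing else separates the pair and no second structural change needs to be accounted for: the fact that compounds 2 and 4 differ only in the configuration as drawn

The compounds shown leave open whether the two configurations at this carbon would remain equally hard to separate on the read-out if the shared core carried a different group, such as a carboxylic acid or a primary amine, in place of the chlorine on the benzoyl group. Compound 1 gives >= 511000 nM, which is a limit of the assay and not a number, so it offers no measured figure against which any further change could be read.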